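A few compounds are considered here, and "the series" means these few. Any claim that something is new, unique, unknown or untested is made for them only; others in the source may bear on it.

Measured in a functional assay on T47D cells (Homo sapiens) for antiproliferative activity, read by MTT assay, with a stated time of 72 h; a lower number here means a stronger inhibitor, a higher number a weaker inhibitor:
Compound 1 `CCCn1ccnc1-c1cc(OC)c(OC)c(OC)c1`: > 100000 nM
Compound 2 `COc1cc(-c2nccn2C(C)C)cc(OC)c1OC`: > 100000 nM
Compound 3 `CCCCn1ccnc1-c1cc(OC)c(OC)c(OC)c1`: > 100000 nM

Compound 3 gives > 100000 nM, and this is a limit of the assay, not a number. The whole set reads the same way: the limit of > 100000 nM in this assay, at which 3 of the 3 values shown sit.

Compound 4 `COc1cc(-c2nccn2CC(C)C)cc(OC)c1OC` has the same atoms as compound 3, joined differently: isopropyl in place of propyl on a saturated chain carbon bound to an aromatic nitrogen. Cut one bond further out, the same difference reads butyl to isobutyl. The closest measured change is the same exchange of groups made on an aromatic nitrogen, a step that the two limits leave unreadable from compound 1 to compound 2. The other two changes in that chain are a step that the two limits leave unreadable from compound 1 to compound 3 and a step that the two limits leave unreadable from compound 2 to compound 3. None of the three has a readable size, so no size or direction can be carried over to this assay, and no step beyond the scatter is expected. The expectation leans on compound 2, which carries an isopropyl group and gives > 100000 nM, again a limit. The expected change is a number no higher from compound 3 to compound 4 (the limit leaves the size open). For compound 4 the estimated value is 100000 nM, with an expected range from 40000 nM to 200000 nM. A report as a limit alone is the likeliest outcome.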

Compound 4, half-maximal inhibitory concentration: > 100000 nM
Compound 4: no number, only a limit; the forecaster's own chance of this, stated with the estimate: 85%; the middle value lies on the limit itself.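

In this assay compound 4 gives > 100000 nM and this is a limit of the assay, not a number. Among the compounds shown here, no step from compound 1, compound 2 or compound 3 to compound 4 can be read. The compounds shown leave open how the propyl, isopropyl, butyl and isobutyl compounds would rank, because all of them stand at the same reading: the limit of > 100000 nM in this assay, at which 4 of the 4 values shown sit.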